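Three limits in hand and a fourth compound awaiting measurement

The compounds below may be only part of what the source reports. "The series", "measured", "known", "first", "only" and "open" are said of these compounds alone.

In a functional assay on MCF7 cells (Homo sapiens) for antiproliferative activity, read by MTT assay, with a stated time of 48 h (on this read-out lower numbers stand for stronger inhibition and higher numbers for weaker inhibition), compound 1 `COc1cc(-c2cccc3nc(-c4ccccc4)oc23)cc(OC)c1OC` gives only a limit, > 25000 nM. Compound 2 `COc1cc(-c2cccc3nc(-c4ccc(F)cc4)oc23)cc(OC)c1OC` also stops at a limit in this assay, > 25000 nM. Compound 3 `COc1cc(-c2cccc3nc(-c4cccc(O)c4)oc23)cc(OC)c1OC` likewise returns a limit, > 25000 nM. Compound 1 therefore has no numbered place among the three, and because the limit of > 25000 nM in this assay, at which 3 of the 3 values shown sit, the steps a step that the two limits leave unreadable from compound 1 to compound 2, a step that the two limits leave unreadable from compound 1 to compound 3 and a step that the two limits leave unreadable from compound 2 to compound 3 cannot be sized. Compound 4 `COc1cc(-c2nc3cccc(-c4cc(OC)c(OC)c(OC)c4)c3o2)ccc1O` differs from compound 1 by 4-hydroxy-3-methoxyphenyl in place of phenyl on an aromatic carbon. Going by the values given here, no measured step matches this change, and those measured give no direction, so no step beyond the scatter can be expected from them; a further limit seems the most likely outcome. Compound 4 is therefore estimated at 30000 nM, ranging from 8000 nM to 100000 nM, with a step that the limit leaves unreadable from compound 1 to compound 4 expected.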

Compound 4, half-maximal inhibitory concentration: > 25000 nM
Compound 4: only a limit was reported; the forecaster's own chance of this, stated with the estimate: 75%; the middle value lies beyond the limit too.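

In this assay compound 4 gives > 25000 nM, which is again a limit. Going by these compounds alone, no step to compound 4 from compound 1, compound 2 or compound 3 can be read. The compounds shown leave open what change to the shared core, if any, would give a measurable value in this assay.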